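From Acetoxy to Methoxy at an Assay Limit

A few compounds are considered here, and "the series" means these few. Any claim that something is new, unique, unknown or untested is made for them only; others in the source may bear on it.

Compound 2 `CCc1cccc2c(OC(C)=O)c(-c3occ(C)c3COC(C)=O)ccc12` carries an acetyl on an oxygen on an aromatic ring. In a functional assay on KBVIN cells (Homo sapiens) for cytotoxicity, read by MTT assay, with a stated time of 72 h (a higher number here means that more compound is needed for the effect, a lower number that less compound is needed), compound 2 gives > 10 ug/mL as its reading, which is a limit and not a number. Compound 1 `CCCOC(=O)c1c(C)coc1-c1ccc2c(CC)cccc2c1OC` gives > 10 ug/mL as its reading, and that too is a limit. Within the data shown here, compound 2 therefore has no exact place on the scale, and no measured step yet shows what any single group does.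

Compound 3 `CCc1cccc2c(OC)c(-c3occ(C)c3COC(C)=O)ccc12` differs from compound 2 in one place, with methyl in place of acetyl on an oxygen on an aromatic ring and the rest unchanged. In other words, acetoxy becomes methoxy. Among the measured compounds shown here, compound 1 and compound 2 are the only guide the limit of > 10 ug/mL in this assay, at which 2 of the 2 values shown sit, and they give no sign of a large shift, so another limit reading in this assay would be no surprise. The estimated change is a step that the limit leaves unreadable from compound 2 to compound 3 in size, expected to stay within the scatter with no direction favoured. For compound 3 the expected value is 12 ug/mL with 5 ug/mL and 30 ug/mL as the ends of the estimated range.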

Compound 3, concentration for half-maximal effect: > 10 ug/mL
Compound 3 ended at the assay's limit; the forecaster's own chance of this, stated with the estimate: 70%; the middle value lies beyond the limit too.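

No new step can be read for compound 1, compound 2 and compound 3 in this assay: their readings are limits and not numbers, so the change from acetoxy to methoxy has no readable size. The compounds shown leave open how far each lies from that limit and whether any single group changes the reading, as all share one reading: the limit of > 10 ug/mL in this assay, at which 3 of the 3 values shown sit.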